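Methoxy to fluoro on the pendant phenyl ring

A few compounds are considered here, and "the series" means these few. Any claim that something is new, unique, unknown or untested is made for them only; others in the source may bear on it.

Two compounds of the series have been run in an ADME assay on microsomes from liver (Mus musculus), read by LC-MS, using NADPH, with a stated time of 30 min, tested at 1 uM; on this read-out lower numbers stand for a less stable compound and higher numbers for a more stable compound. Compound 1 `C[C@H](Nc1nc(N)nc(N)c1C#N)c1c(C2CC2)c(=O)n2cc(F)ccc2c1-c1ccc(F)cc1` gives 75%, and compound 2 `COc1ccc(-c2c([C@H](C)Nc3nc(N)nc(N)c3C#N)c(-c3ccccc3)c(=O)n3cc(F)ccc23)cc1` gives 82%; the two numbers lie within the scatter of each other, so neither can be set apart. Compound 3 `C[C@H](Nc1nc(N)nc(N)c1C#N)c1c(-c2ccccc2)c(=O)n2cc(F)ccc2c1-c1ccc(F)cc1` has not yet been measured in this assay; it differs from compound 2 by fluoro in place of methoxy on an aromatic carbon. Among the measured compounds shown here, no step between measured compounds covers this change. Compound 1 already carries the 4-fluorophenyl group and sits close to compound 2, so for the step from compound 2 to compound 3 no move beyond the scatter is expected, a number 6 percentage points lower from compound 2 to compound 3 (within the scatter). Compound 3 is expected to give about 76%, within 60% to 90%.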

Compound 3, percent of the compound remaining: 83%
Beside the measured number, compound 3's estimate is 7 percentage points below it, and the stated range covers the measured number.
By their numbers in this assay, from the lowest: compounds 1, 2 and 3 (each within the scatter of the next).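

In this assay, fluoro in place of methoxy on the pendant ring now has a direct reading, a number 1 percentage points higher from compound 2 to compound 3 (within the scatter), so 4-methoxyphenyl and 4-fluorophenyl cannot be told apart at this position. Phenyl in place of cyclopropyl on the shared core gives a number 8 percentage points higher from compound 1 to compound 3 (within the scatter), so that second place shows no separation either. Nothing at hand bears on why these steps come out as they do.

Still open, as far as these compounds go, is whether an amine or a carboxylic acid on that aromatic carbon would move the number beyond the scatter. The same question stands for a longer chain in place of phenyl.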